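This account rests on a few compounds, and the source may have more. Where it says the series, first, only, none or still open, it means among the compounds named here.

Three compounds share one core and differ only in the benzyl group bound to the sulfur. Compound 1 `Cc1cc(S(=O)(=O)/N=C(\N)n2nccc2-c2ccccc2)c(SCc2cccc(Cl)c2)cc1Cl` carries a 3-chlorobenzyl group; in a functional assay on HeLa cells (Homo sapiens) for cytotoxicity, read by MTT assay, with a stated time of 72 h (on this read-out higher numbers stand for weaker inhibition and lower numbers for stronger inhibition), compound 1 gives 10000 nM. Compound 2 `Cc1cc(S(=O)(=O)/N=C(\N)n2nccc2-c2ccccc2)c(SCc2cccc(C(F)(F)F)c2)cc1Cl` differs from compound 1 by trifluoromethyl in place of chloro on an aromatic carbon, and in this assay compound 2 gives 19000 nM; that change made a 1.9-fold higher number from compound 1 to compound 2 (0.28 log units; within the scatter). Compound 3 `Cc1cc(S(=O)(=O)/N=C(\N)n2nccc2-c2ccccc2)c(SCc2ccccc2Cl)cc1Cl` differs from compound 1 in the core arrangement by 2-chlorophenyl in place of 3-chlorophenyl on a saturated chain carbon bound to a sulfur, and in this assay compound 3 gives 19000 nM, a step of a 1.9-fold higher number from compound 1 to compound 3 (0.28 log units; within the scatter); from compound 2 to compound 3 the data show no change at the digits printed from compound 2 to compound 3 (within the scatter).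

Compound 4 `Cc1cc(S(=O)(=O)/N=C(\N)n2nccc2-c2ccccc2)c(SCc2ccccc2C(F)(F)F)cc1Cl` has not yet been measured. It differs from compound 3 by trifluoromethyl in place of chloro on an aromatic carbon, the same kind of change as that from compound 1 to compound 2, but here the place is ortho to a large group, where before it was meta to a large group. Since the earlier step was a 1.9-fold higher number from compound 1 to compound 2 (0.28 log units; within the scatter), the step from compound 3 to compound 4 is expected to be of similar size, a 1.3-fold higher number from compound 3 to compound 4 (0.12 log units; within the scatter). Compound 4 is therefore estimated at 25000 nM, between 10000 nM and 60000 nM, in this assay.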

Compound 4, half-maximal inhibitory concentration: 20000 nM
Estimate against measurement, compound 4: 1.3-fold (0.10 log units) above; measured number inside the range.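

In this assay, trifluoromethyl in place of chloro gives a 1.1-fold higher number from compound 3 to compound 4 (0.02 log units; within the scatter), while the other two steps that reach the new compound are a 1.1-fold higher number from compound 2 to compound 4 (0.02 log units; within the scatter) and a 2.0-fold higher number from compound 1 to compound 4 (0.30 log units; within the scatter). Set beside the earlier case, the same change gives two steps that cannot be told apart: the same change on two cores in this assay, a 1.9-fold higher number (0.28 log units; within the scatter) from compound 1 to compound 2 and a 1.1-fold higher number (0.02 log units; within the scatter) from compound 3 to compound 4, 1.8-fold (0.26 log units) apart, within the scatter of two such steps This shows only that, across these two pairs, the swap of chloro for trifluoromethyl leaves the number within the scatter; it does not show that the change has a real effect of its own, nor that it would behave alike on any other core in this series.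

The compounds shown leave open whether an amine, a carboxylic acid or a nitrile on the benzyl group would give a step beyond the scatter in this assay. They also leave open what a longer chain in place of the benzyl group on the sulfur would do.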